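Swapping the cyano-diazine on the shared core

The source may report more compounds than this note shows. Statements on the series, on what has been measured and on what is new or still open speak of the compounds shown alone.

- compound 1 `N#Cc1ccc(N2CCC(C(=O)N3N=CC[C@H]3c3cc(F)cc(F)c3)CC2)nn1`: > 8 h
- compound 2 `O=C(C1CCN(c2ccncn2)CC1)N1N=CC[C@H]1c1ccccc1`: 3.3 h

In an ADME assay on cells (Hepatocyte, Homo sapiens) for metabolic stability (a lower number here means that the compound disappears faster, a higher number that the compound lasts longer), compound 1 gives > 8 h, which is a limit of the assay and not a number. Compound 2 gives 3.3 h in this assay. Compound 3 `N#Cc1cnc(N2CCC(C(=O)N3N=CC[C@H]3c3cc(F)cc(F)c3)CC2)cn1` keeps the core of compound 1 and carries 5-cyanopyrazin-2-yl on the amine nitrogen in a ring: a group of 8 heavy atoms (5 carbon, 3 nitrogen; one six-membered aromatic ring with 2 hetero atoms) in place of a group of 8 heavy atoms (5 carbon, 3 nitrogen; one six-membered aromatic ring with 2 hetero atoms), on an amine nitrogen in a ring. Within the data shown here, no measured pair covers this change. The expected step is an at least 1.1-fold lower number from compound 1 to compound 3 (0.05 log units; that floor lies within the scatter), a small drop or none beyond the scatter in this assay. For compound 3 the estimated half-life is 7 h, with an expected range of 3.5 h to 14 h.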

Compound 3, half-life: 3.3 h
Estimate against measurement, compound 3: 2.1-fold (0.33 log units) above, outside the stated range (below it).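

On the amine nitrogen of the six-membered ring, the arrangement of the ring atoms and nitrile counts even with identical atoms: in this assay, the 5-cyanopyrazin-2-yl group gives an at least 2.4-fold lower number from compound 1 to compound 3 (0.38 log units; beyond the scatter). The full size of this step cannot be read, because compound 1 stands at a limit of the assay: the limit of > 8 h in this assay, at which 1 of the 3 values shown sits.

Compound 2 differs from compound 1 and compound 3 in more than one place, so it isolates no single change. Still open, as far as these compounds go, are how a methoxy group or a primary amide in place of the nitrile would behave, and what the fluorine atoms contribute alone.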